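The source may hold more compounds than are shown below. What is called first, only, known or untested is meant among the compounds shown, and "the series" means these compounds.

Measured in a functional assay on PC-3 cells (Homo sapiens) for cytotoxicity, read by MTT assay, with a stated time of 72 h; on this read-out higher numbers stand for weaker inhibition and lower numbers for stronger inhibition:
compound 1 `Cc1cc(Nc2ccc(Cl)cc2)nc(SCc2nc3ccccc3[nH]2)n1` – 36000 nM
compound 2 `Cc1cc(NCCO)nc(SCc2nc3ccccc3[nH]2)n1` – > 100000 nM; this is a limit of the assay, not a number
compound 3 `Cc1ccc(Nc2cc(C)nc(SCc3nc4ccccc4[nH]3)n2)cc1` – 56000 nM

Compound 2 therefore stands only at the limit of > 100000 nM in this assay, at which 1 of the 3 values shown sits, with no number of its own. Compound 4 `Cc1cc(N(C)Cc2ccccc2)nc(SCc2nc3ccccc3[nH]2)n1` differs from compound 2 by benzyl(methyl)amino in place of (2-hydroxyethyl)amino on an aromatic carbon. Two measured steps involve the same nitrogen: an at least 2.7-fold higher number from compound 1 to compound 2 (0.44 log units; beyond the scatter) and an at least 1.7-fold lower number from compound 2 to compound 3 (0.25 log units; that floor lies within the scatter). The first lies beyond the scatter; the floor of the second lies within it. Both run in the direction of lower numbers when a group carrying a six-membered aromatic ring replaces the 2-hydroxyethyl group. For compound 4 a modest step down in this assay is expected, an at least 2.0-fold lower number from compound 2 to compound 4 (0.30 log units; that floor lies within the scatter). Compound 4 is estimated at 50000 nM, within 15000 nM to 200000 nM.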

Compound 4, half-maximal inhibitory concentration: > 100000 nM
Compound 4: only a limit was reported (the forecaster's own chance of this, stated with the estimate: 35%); middle value at least 2.0-fold (0.30 log units) away from the limit.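

In this assay, a six-membered aromatic ring on the group does not by itself bring a lower number: an at least 2.7-fold higher number from compound 1 to compound 4 (0.44 log units; beyond the scatter), with benzyl(methyl)amino in place of (4-chlorophenyl)amino. Against compound 3 the same kind of change gives an at least 1.7-fold higher number from compound 3 to compound 4 (0.25 log units; that floor lies within the scatter), so only the comparison with compound 1 separates clearly. The step between compound 2 and compound 4 cannot be read, since each compound has only a limit: the limit of > 100000 nM in this assay, at which 2 of the 4 values shown sit.

Open, on these data alone, is whether the methyl on the nitrogen or the carbon link to the ring drives the difference. Plain benzylamino and (4-chlorophenyl)(methyl)amino would separate these two changes.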